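The compounds below may be only part of what the source reports. "The series", "measured", "known", "first", "only" and "open" are said of these compounds alone.

Working notes on the series. The shared core carries an amide on the ring and, in three of the four compounds, a second amide to a cyclopropyl; the compounds differ in the aromatic group on the saturated chain carbon bound to the aromatic nitrogen. In a physicochemical assay for lipophilicity, at pH 7.4 (a higher number here means a more lipophilic compound, a lower number a more polar compound), compound 1 `CNC(=O)c1cc(C(=O)NC2CC2)cn(Cc2cccc3[nH]ccc23)c1=O` gives 2.9, compound 2 `CNC(=O)c1cc(C(=O)NC2CC2)cn(Cc2nccc3[nH]ccc23)c1=O` gives 1.7 and compound 3 `CNC(=O)c1ccc(=O)n(Cc2ccccc2)c1` gives 1.6. Compound 2 stands second highest of the three numbers: compound 3 lies within the scatter of it, while compound 1 lies well above it, the step being a number 1.20 log units lower from compound 1 to compound 2 (beyond the scatter).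

The step from compound 2 to compound 4 `CNC(=O)c1cc(C(=O)NC2CC2)cn(Cc2ccccc2F)c1=O` is a group of 7 heavy atoms (6 carbon, 1 fluorine; one six-membered aromatic ring of carbon only) in place of a group of 9 heavy atoms (7 carbon, 2 nitrogen; one five-membered aromatic ring with 1 hetero atom, one six-membered aromatic ring with 1 hetero atom), on a saturated chain carbon bound to an aromatic nitrogen. Within the data shown here, the only measured step that bears on it is a number 1.20 log units lower from compound 1 to compound 2 (beyond the scatter), where a carbon-only six-membered aromatic ring was exchanged for one with a hetero atom and the number fell by a large amount; the present change goes the other way, back to a carbon-only six-membered ring, though a smaller one than in compound 1. A rise in this assay is therefore expected for compound 4, estimated at a number 0.80 log units higher from compound 2 to compound 4 (beyond the scatter), most likely short of the value of compound 1. Compound 4 is estimated at 2.5, with a range from 2 to 3.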

Compound 4, distribution coefficient: 3
Estimate against measurement, compound 4: 0.50 log units below; the measured number falls inside the stated range.
By their numbers in this assay, from the lowest: compounds 3 and 2 (each within the scatter of the next); then compounds 1 and 4 (each within the scatter of the next).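

On the saturated chain carbon bound to an aromatic nitrogen, 2-fluorophenyl in place of the group of compound 2 brings a number 1.30 log units higher from compound 2 to compound 4 (beyond the scatter) in this assay, a large step in the opposite direction to the one already seen on leaving compound 1. The direct comparison of the two carbon-only six-membered aromatic rings, 2-fluorophenyl in place of 1H-indol-4-yl, gives a number 0.10 log units higher from compound 1 to compound 4 (within the scatter), so among compounds 1, 2 and 4 only compound 2, with its hetero atom in the six-membered aromatic ring, stands apart, while the groups of compound 1 and compound 4 cannot be told apart in this read-out despite their different heavy-atom counts. Nothing measured on the series bears on the reason for these steps.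

As far as these compounds go, it remains open how a phenyl without fluorine, or a phenyl carrying an amine or a carboxylic acid, would stand on this core in this assay. From the compounds shown here alone, compound 3 differs from the others in more than one place, so the contribution of the cyclopropyl amide cannot be read, and a longer chain in place of the cyclopropyl is equally open.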